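The source may report more compounds than this note shows. Statements on the series, on what has been measured and on what is new or still open speak of the compounds shown alone.

Working notes on the series. The core of compound 3 `COC(=O)C[C@H](NC(=O)OC(C)(C)C)C(=O)N(C)C1(C(=O)NCc2ccccc2)CCN(Cc2ccccc2)CC1` carries an N-methyl amide; in an ADME assay on MDCK cells (Canis lupus familiaris) for cytotoxicity, read by microscopy, with a stated time of 72 h (on this read-out lower numbers stand for higher toxicity in this test and higher numbers for lower toxicity in this test), compound 3 gives 20000 nM. Among the compounds with values here, its parent compound 2 `COC(=O)C[C@H](NC(=O)OC(C)(C)C)C(=O)NC1(C(=O)NCc2ccccc2)CCN(Cc2ccccc2)CC1`, which has hydrogen on that nitrogen, gives 100000 nM in this assay, so the step of a 5.0-fold lower number from compound 2 to compound 3 (0.70 log units; beyond the scatter) is the only single-point change measured so far. The open-chain compound 1 `COC(=O)C[C@H](NC(=O)OC(C)(C)C)C(=O)N(Cc1ccc(F)cc1)C(C)(C)C(=O)NCc1ccccc1` gives 20000 nM in this assay, level with compound 3 at the digits shown, so compound 3 and compound 1 together hold the lowest numbers of the three, and compound 2 is the furthest from compound 3.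

Compound 4 `COC(=O)C[C@H](NC(=O)OC(C)(C)C)C(=O)N(Cc1ccc(C(F)(F)F)cc1)C1(C(=O)NCc2ccccc2)CCN(Cc2ccccc2)CC1` has not yet been measured. It differs from compound 3 by 4-(trifluoromethyl)phenyl in place of hydrogen on a saturated chain carbon bound to an amide-type nitrogen. Within the data shown here, the bearing step is the N-methylation from compound 2 to compound 3, which moved the number down modestly; the new change is a further enlargement on the same kind of position, but no measured pair shows what a group of this size does in this assay. A small further lowering or no change beyond the scatter is expected, with the step of a 2.0-fold lower number from compound 3 to compound 4 (0.30 log units; within the scatter) as the working guess. Compound 4 is therefore estimated at 10000 nM in this assay, with a range from 3000 nM to 30000 nM.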

Compound 4, minimum cytotoxic concentration: 84000 nM
Compound 4: middle estimate off by 8.4-fold (0.92 log units), on the low side; measured number above the stated range.
By their numbers in this assay, from the lowest: compounds 1 and 3 (each within the scatter of the next); then compounds 4 and 2 (each within the scatter of the next).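

In this assay the amide-type nitrogen of this core now carries hydrogen, methyl and 4-(trifluoromethyl)benzyl, and the number does not keep falling as the group on it grows: the drop seen with methyl (a 5.0-fold lower number from compound 2 to compound 3 (0.70 log units; beyond the scatter)) is followed by a rise when methyl gives way to 4-(trifluoromethyl)benzyl (a 4.2-fold higher number from compound 3 to compound 4 (0.62 log units; beyond the scatter)). Set against hydrogen on the same nitrogen, 4-(trifluoromethyl)benzyl shows no change beyond the scatter (a 1.2-fold lower number from compound 2 to compound 4 (0.08 log units; within the scatter)), so among these three compounds substitution on this nitrogen does not in itself go with the lower number, and only the methyl compound stands apart from the other two. Nothing at hand bears on the reason for this turn.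

The compounds shown leave open whether the higher number belongs to the benzyl chain itself or to the trifluoromethyl on its ring, a question that a plain benzyl on the same nitrogen would address. Also open, from the compounds shown here alone, is whether an ethyl, a longer chain, or a benzyl carrying an amine or a carboxylic acid would read with compound 3 or with compound 2.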